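Replacing pyridin-2-yl with 5-methylthiophen-2-yl on a shared core

The source may report more compounds than this note shows. Statements on the series, on what has been measured and on what is new or still open speak of the compounds shown alone.

Compound 1 `O=C1/C(=C\c2ccc(O)c(O)c2)S/C(=N/c2ccccc2)N1Cc1ccncc1` and compound 2 `O=C1/C(=C\c2ccccn2)S/C(=N/c2ccccc2)N1Cc1ccncc1` share one core and differ in a single group. In an ADME assay on HEK293 cells (Homo sapiens) for cytotoxicity, read by MTT assay, with a stated time of 48 h (on this read-out higher numbers stand for weaker inhibition and lower numbers for stronger inhibition), compound 1 gives 230000 nM and compound 2 gives 161000 nM, so the two numbers lie within the usual scatter of each other. Compound 3 `Cc1ccc(/C=C2/S/C(=N/c3ccccc3)N(Cc3ccncc3)C2=O)s1` changes the same place on the core: 5-methylthiophen-2-yl in place of pyridin-2-yl on a double-bonded chain carbon bound to a double-bonded ring carbon. Here 5-methylthiophen-2-yl stands in place of pyridin-2-yl on a double-bonded chain carbon bound to a double-bonded ring carbon. Among the compounds with values here, the only measured step at this place, a 1.4-fold lower number from compound 1 to compound 2 (0.15 log units; within the scatter), replaced 3,4-dihydroxyphenyl with pyridin-2-yl and stayed within the scatter. A single step is thin evidence, but it gives no reason to expect a change beyond the scatter in this assay. The estimated step is a 1.1-fold higher number from compound 2 to compound 3 (0.05 log units; within the scatter). For compound 3 the expected value is 180000 nM, with a range of 85000 nM to 380000 nM.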

Compound 3, half-maximal inhibitory concentration: 146000 nM
Compound 3: the middle estimate sits 1.2-fold (0.09 log units) above what was measured; measured number inside the range.
By their numbers in this assay, from the lowest: compounds 3, 2 and 1 (each within the scatter of the next).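

In this assay the third group at this place gives a 1.1-fold lower number from compound 2 to compound 3 (0.04 log units; within the scatter) and also a 1.6-fold lower number from compound 1 to compound 3 (0.20 log units; within the scatter) so neither new step leaves the scatter. Three different groups have now stood on the double-bonded chain carbon bound to a double-bonded ring carbon, and even exchanging the six-membered aromatic ring of pyridin-2-yl for the five-membered aromatic ring of 5-methylthiophen-2-yl does not separate compound 2 from compound 3. No measurement shown here gives a cause for these numbers staying together.

As far as these compounds go, all three groups contain an aromatic ring, so it remains open whether a carboxylic acid, an amine or a longer open carbon chain at this place would move the number beyond the scatter. From the compounds shown here alone, whether changes elsewhere on the shared core would do so also remains open.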